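The source may report more compounds than this note shows. Statements on the series, on what has been measured and on what is new or still open speak of the compounds shown alone.

Compound 1 `O=C(OC[C@H]1CN(c2ccc(-n3cc(-c4ccccn4)cn3)c(F)c2)C(=O)O1)c1ccccc1` gives 4.21 in a physicochemical assay for lipophilicity, read by HPLC, measured as octanol-water partition; a higher number here means a more lipophilic compound, a lower number a more polar compound. Compound 2 `CCC(=O)NC[C@H]1CN(c2ccc(-n3cc(-c4ccccn4)cn3)c(F)c2)C(=O)O1` gives 2.2 in this assay, and the step of a number 2.01 log units lower from compound 1 to compound 2 (beyond the scatter). For compound 3 `O=C1O[C@@H](CNC(=O)C(F)(F)F)CN1c1ccc(-n2cc(-c3ccccn3)cn2)c(F)c1` this assay reports only a limit, >= 1.78, namely (the limit of >= 1.78 in this assay, at which 1 of the 3 values shown sits). The steps a step that the limit leaves unreadable from compound 1 to compound 3 and a step that the limit leaves unreadable from compound 2 to compound 3 therefore cannot be sized. Compound 4 `NC(=O)[C@H]1CN(c2ccc(-n3cc(-c4ccccn4)cn3)c(F)c2)C(=O)O1` differs from compound 3 in one place: carbamoyl in place of (((trifluoromethyl)carbonyl)amino)methyl on a saturated ring carbon. Among the compounds with values here, the only readable guide is the move from benzoyloxy to propanoylamino, which lowered this assay strongly from compound 1 to compound 2. A further drop toward the polar side is expected, so compound 4 is estimated at 1.2, within 0.5 to 1.9, which would mean an expected step of a number at least 0.58 log units lower from compound 3 to compound 4 (beyond the scatter).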

Compound 4, partition coefficient: 1.59
Compound 4: the middle estimate sits 0.39 log units below what was measured; the measured number falls inside the stated range.
By their numbers in this assay, from the lowest: compound 4; then compound 2; then compound 1.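

Carbamoyl on this saturated ring carbon takes the number down again in this assay, with a number 0.61 log units lower from compound 2 to compound 4 (beyond the scatter) and a number 2.62 log units lower from compound 1 to compound 4 (beyond the scatter), so the drop does not end with the swap to propanoylamino. Set against compound 3, the result gives only a number at least 0.19 log units lower from compound 3 to compound 4 (that floor lies within the scatter). Compound 3 holds a limit, so its steps from compound 1 and compound 2 cannot be read: the limit of >= 1.78 in this assay, at which 1 of the 4 values shown sits.

From the compounds shown here alone, whether an amine or a carboxylic acid on this ring carbon would sit lower or higher in this assay stays open.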